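The source may hold more compounds than are shown below. What is called first, only, known or untested is meant among the compounds shown, and "the series" means these compounds.

Of the compounds shown here, three have been measured in an assay on cells for inhibition of ubiquitin carboxyl-terminal hydrolase isozyme L5 (Homo sapiens), read by fluorescence, with a stated time of 30 min; a higher number here means a weaker inhibitor, a lower number a stronger inhibitor. Compound 1, `Nc1ccc(-c2cn(Cc3cc(C(=O)O)cc(-c4cccc(C(=O)O)c4)c3)nn2)cc1`, gives 32900 nM. Compound 2, `Nc1cccc(-c2cn(Cc3cc(C(=O)O)cc(-c4ccccc4C(=O)O)c3)nn2)c1`, gives 72600 nM. Compound 3, `Nc1ccc(-c2cn(Cc3cccc(-c4ccccc4C(=O)O)c3)nn2)cc1`, gives 116000 nM. All three numbers are high, so none of these compounds is a strong inhibitor. Compound 2 holds the second highest of the three numbers; its value and that of compound 3 lie within the usual scatter of each other, so no order between them can be read, while compound 1 sits clearly lower, a gap beyond the scatter.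

Compound 4, `O=C(O)c1cc(Cn2cc(-c3cccnc3)nn2)cc(-c2ccccc2C(=O)O)c1`, has not yet been measured. It differs from compound 2 in one place: pyridin-3-yl in place of 3-aminophenyl on an aromatic carbon. Among the compounds with values here, no pair of measured compounds shows what such a change does here, so the expectation rests only on the weak numbers already seen. The step from compound 2 to compound 4 is expected to be small, a 1.1-fold higher number from compound 2 to compound 4 (0.04 log units; within the scatter), not clearly beyond the scatter in either direction. Compound 4 is therefore estimated at 80000 nM, with a likely range from 30000 nM to 200000 nM.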

Compound 4, half-maximal inhibitory concentration: 252000 nM
Estimate against measurement, compound 4: 3.2-fold (0.50 log units) below, outside the stated range (above it).
By their numbers in this assay, from the lowest: compound 1; then compounds 2 and 3 (each within the scatter of the next); then compound 4.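

Within the data shown here, this is the first step that changes only one place. In this assay, putting pyridin-3-yl in place of 3-aminophenyl on this aromatic carbon of the five-membered ring gives a 3.5-fold higher number from compound 2 to compound 4 (0.54 log units; beyond the scatter), so this position is not indifferent to the group it carries, even among weak inhibitors. The swap both removes the amine and places a nitrogen in the six-membered ring, and no measurement here says why the number rises.

A plain phenyl at this position would help separate the two parts of the swap, showing whether the amine or the ring nitrogen accounts for the step. On these data alone, whether pyridin-3-yl has a similar effect on the core of compound 1 also remains open.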